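This account rests on a few compounds, and the source may have more. Where it says the series, first, only, none or still open, it means among the compounds named here.

Compound 2 `CC(C)(C)C(=O)OCO[P@@]1(=O)OCC(C)(C)[C@H](C(=O)NCCC(=O)OCCS(C)(=O)=O)O1` is the starting point of this step. In an ADME assay on blood (Homo sapiens) for pharmacokinetics (a higher number here means that the compound lasts longer, a lower number that the compound disappears faster), compound 2 gives < 0.16 h, which is a limit of the assay rather than a number, so compound 2 stands at the low end of the three values shown: the limit of < 0.16 h in this assay, at which 1 of the 3 values shown sits. The other two compounds sit at the opposite end. Compound 1 `CCc1cc(C(=O)OCO[P@@]2(=O)OCC(C)(C)[C@H](C(=O)NCCC(=O)OC)O2)n(C)n1` gives >= 0.97 h in this assay, again a limit of the assay. Compound 3 `COC(=O)CCNC(=O)[C@@H]1OP(=O)(Oc2ccc(F)cc2)OCC1(C)C` gives > 1 h in this assay, also a limit. Compound 4 `CC(C)(C)C(=O)OCO[P@@]1(=O)OCC(C)(C)[C@H](C(=O)NCCC(=O)OC2CCN(Cc3ccccc3)C2)O1` has not been measured. It differs from compound 2 in one place, (1-benzylpyrrolidin-3-yl in place of 2-(methylsulfonyl)ethyl on an oxygen next to a carbonyl group), that is, 1-benzylpyrrolidin-3-yl in place of 2-(methylsulfonyl)ethyl on an oxygen next to a carbonyl group. Among the measured compounds shown here, no measured pair traces this change, so the expectation rests on the spread between compound 2 at the limit of < 0.16 h in this assay, at which 1 of the 3 values shown sits, and compounds 1 and 3 at the limit of >= 0.97 h in this assay, at which 1 of the 3 values shown sits, and (the limit of > 1 h in this assay, at which 1 of the 3 values shown sits). For compound 4 the expected step is an at least 2.5-fold higher number from compound 2 to compound 4 (0.39 log units; beyond the scatter), upward and beyond the scatter. The estimate for compound 4 in this assay is 0.4 h, with a range from 0.1 h to 1.5 h.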

Compound 4, half-life: 0.19 h
Compound 4: middle estimate off by 2.1-fold (0.32 log units), on the high side; low and high end bracket the measured number.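

In this assay, among the compounds shown here, compound 4 gives 0.19 h, the first value at this position that is a number and not a limit of the assay, with 1-benzylpyrrolidin-3-yl on an oxygen next to a carbonyl group. The value of compound 2, which carries 2-(methylsulfonyl)ethyl in that place, remains a limit: the limit of < 0.16 h in this assay, at which 1 of the 4 values shown sits. The change can therefore be read only as a floor, an at least 1.1-fold higher number from compound 2 to compound 4 (0.07 log units; that floor lies within the scatter), so the compounds shown do not establish that this larger ring-bearing group alters the half-life at all.

Going by these compounds, the true size of the step stays open as long as compound 2 has only a limit. Also open, on these data alone, is how an open-chain amine or a free carboxylic acid in the same place would behave in this assay, and whether the benzyl group of 1-benzylpyrrolidin-3-yl plays any part.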